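Replacing one phenyl group in compound 3

This account rests on a few compounds, and the source may have more. Where it says the series, first, only, none or still open, it means among the compounds named here.

In a functional assay on MCF7 cells (Homo sapiens) for inhibition, read by sulforhodamine B assay (on this read-out lower numbers stand for stronger inhibition of growth and higher numbers for weaker inhibition of growth), compound 3 (`FC(F)(F)c1ccc(-c2ccc(-c3ccc(-c4nc5ccccc5[nH]4)cc3)cc2)cc1`) gives 41400 nM and stands highest of the three measured numbers, while compound 1 (`Cc1ccc2[nH]c(-c3ccc(-c4ccc(-c5ccc(N(C)C)cc5)cc4)cc3)nc2c1`) gives 3130 nM and compound 2 (`COc1ccc(-c2ccc(-c3ccc(-c4nc5cc(C)ccc5[nH]4)cc3)cc2)cc1OC`) gives 190 nM there. Compound 4 (`Clc1cccc(-c2ccc(-c3ccc(-c4nc5ccccc5[nH]4)cc3)cc2)c1`) has not been measured. It carries 3-chlorophenyl in place of 4-(trifluoromethyl)phenyl on an aromatic carbon. Within the data shown here, no measured step starts from compound 3, so the nearest guide is the exchange of another substituted phenyl group, a 16-fold lower number from compound 1 to compound 2 (1.22 log units; beyond the scatter) which is large. That guide shows such exchanges can matter but gives no direction here. Compound 3 at 41400 nM holds the highest number, so the expected change in this assay points downward. The estimated change is a 4.6-fold lower number from compound 3 to compound 4 (0.66 log units; beyond the scatter) in size. Compound 4 is expected at 9000 nM within a range of 1800 nM to 45000 nM as a rough estimate.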

Compound 4, concentration for 50% growth inhibition: 36300 nM
Compound 4: the middle estimate sits 4.0-fold (0.61 log units) below what was measured, within the range that was stated.
By their numbers in this assay, from the lowest: compound 2; then compound 1; then compounds 4 and 3 (each within the scatter of the next).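

In this assay, putting 3-chlorophenyl in place of 4-(trifluoromethyl)phenyl leaves the number within the scatter, a 1.1-fold lower number from compound 3 to compound 4 (0.06 log units; within the scatter). So not every exchange of one substituted phenyl group for another at this end of the molecule moves the number, although the earlier step did, a 16-fold lower number from compound 1 to compound 2 (1.22 log units; beyond the scatter). No measurement here explains why these two groups read alike.

Still open, as far as these compounds go, is whether 3,4-dimethoxyphenyl would give a lower number on the core of compound 3, which lacks the methyl of compound 2. Also open, from the compounds shown here alone, is what a carboxylic acid on this ring would do.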